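Dropping the Basic Side Chain from a Quinazoline Urea

The source may hold more compounds than are shown below. What is called first, only, known or untested is meant among the compounds shown, and "the series" means these compounds.

Measured compounds:
compound 1 `O=C(Nc1ccc(CN2CCCC2)cc1)Nc1ccc2ncnc(Nc3cccc(C(F)(F)F)c3)c2c1` – 1360 nM
compound 2 `CCN(CC)Cc1ccc(NC(=O)Nc2ccc3ncnc(Nc4cccc(C(F)(F)F)c4)c3c2)cc1` – 3980 nM

Among the compounds with values here, in a functional assay on A-431 cells (Homo sapiens) for antiproliferative activity, read by MTT assay, with a stated time of 72 h (a higher number here means a weaker inhibitor, a lower number a stronger inhibitor), compound 2 holds the highest number of the two, and the only step known is a 2.9-fold higher number from compound 1 to compound 2 (0.47 log units; beyond the scatter). Compound 3 `O=C(Nc1ccccc1)Nc1ccc2ncnc(Nc3cccc(C(F)(F)F)c3)c2c1` differs from compound 2 by hydrogen in place of (diethylamino)methyl on an aromatic carbon. Within the data shown here, no measured step removes this group entirely, so the one step gives only a hint that changes at this position matter modestly. The step of a 1.3-fold higher number from compound 2 to compound 3 (0.10 log units; within the scatter) is therefore expected to be small, slightly upward. Compound 3 is estimated at 5000 nM, within 1500 nM to 16000 nM.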

Compound 3, half-maximal inhibitory concentration: > 10000 nM
Compound 3: a limit, no number; the forecaster's own chance of this, stated with the estimate: 10%; middle value at least 2.0-fold (0.30 log units) away from the limit.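

The reading for compound 3 in this assay is a limit and not a number: the limit of > 10000 nM in this assay, at which 1 of the 3 values shown sits.

Hydrogen in place of (diethylamino)methyl gives an at least 2.5-fold higher number from compound 2 to compound 3 (0.40 log units; beyond the scatter), and hydrogen in place of (pyrrolidin-1-yl)methyl gives an at least 7.3-fold higher number from compound 1 to compound 3 (0.86 log units; beyond the scatter). So this position matters for more than the choice of amine: both compounds that carry a side chain there stand clearly apart from the compound with bare hydrogen.

Still open, on these data alone, is whether the amine itself counts or any group there would serve. A plain methyl, a carboxylic acid, or the same amine on a longer chain would separate these possibilities.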